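The compounds below may be only part of what the source reports. "The series", "measured", "known", "first", "only" and "open" are said of these compounds alone.

Measured in an assay on cells for agonist activity at ecdysone receptor (Bombyx mori), read by a luciferase reporter, with a stated time of 24 h (a higher number here means that more compound is needed for the effect, a lower number that less compound is needed), so far are three compounds. Compound 1, `CCc1ccc(C(=O)NN(C(=O)c2ccccc2Cl)C(C)(C)C)cc1`, gives 5.75 nM. Compound 3, `CCCCN(NC(=O)c1ccccc1)C(=O)c1ccccc1`, gives 7080 nM. Compound 2, `CN(NC(=O)c1ccccc1)C(=O)c1ccccc1`, gives only a limit of this assay, > 100000 nM.

Among the two numbers shown, compound 3 holds the highest; its nearest neighbour is compound 1, which sits a long way lower. Within the data shown here, the one measured step relating to the chain on the amide-type nitrogen is an at least 14-fold lower number from compound 2 to compound 3 (1.14 log units; beyond the scatter), which shows that lengthening that chain from hydrogen to propyl brings the number down by a large margin, though compound 2 rests at the limit described by the limit of > 100000 nM in this assay, at which 1 of the 3 values shown sits, so the true size of that step is not fixed.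

Compound 4, `CC(C)CN(NC(=O)c1ccccc1)C(=O)c1ccccc1`, differs from compound 3 in one place: isopropyl in place of propyl on a saturated chain carbon bound to an amide-type nitrogen. Among the measured compounds shown here, no measured step covers this exact change. Compound 1, carrying a larger branched group on that nitrogen, shows a far lower number than compound 3, and the step of an at least 14-fold lower number from compound 2 to compound 3 (1.14 log units; beyond the scatter) shows the chain at that place matters. The change to the branched group is therefore expected to lower the number only moderately, estimated as a 2.8-fold lower number from compound 3 to compound 4 (0.45 log units; beyond the scatter). Compound 4 is thus estimated at 2500 nM, within a range from 700 nM to 10000 nM.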

Compound 4, half-maximal effective concentration: 2880 nM
Compound 4: the middle estimate sits 1.2-fold (0.06 log units) below what was measured; low and high end bracket the measured number.
By their numbers in this assay, from the lowest: compound 1; then compound 4; then compound 3. At a limit, above all of these: compound 2.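

In this assay, this position responds not only to the presence of a carbon chain but also to how that chain is arranged: with the same count of carbon atoms, the change from propyl to isopropyl gives a 2.5-fold lower number from compound 3 to compound 4 (0.39 log units; beyond the scatter). This effect of arrangement is modest, and it is smaller than the large change seen when isopropyl replaces hydrogen, which gives an at least 34-fold lower number from compound 2 to compound 4 (1.54 log units; beyond the scatter). That larger step starts from a limit, so it gives no exact size: the limit of > 100000 nM in this assay, at which 1 of the 4 values shown sits.

The compounds shown leave open whether a longer chain such as pentyl, a ring such as cyclohexyl, or an amine or a carboxylic acid on a saturated chain carbon bound to an amide-type nitrogen would move the number further, and in which direction. They also leave open how much of the low number of compound 1 comes from the group at this place, since no listed step links compound 1 to compound 3 or compound 4 through a single change.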